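The source may hold more compounds than are shown below. What is called first, only, known or untested is meant among the compounds shown, and "the series" means these compounds.

For the measured compounds named here, compound 2 `CCC(=O)NCCCc1ccccc1OC` is, on the numbers so far, the stronger of only two compounds tested in an assay for binding affinity to melatonin receptor (Gallus gallus); on this read-out higher numbers stand for weaker inhibition and lower numbers for stronger inhibition. In this assay compound 2 gives 374 nM. Going by the values given here, the only other measured compound, compound 1 `COc1cccc(CNC(C)=O)c1`, carries a different kind of linkage between the amide and the ring, and in this assay compound 1 gives 57000 nM; the gap between the two lies far beyond the usual scatter, so compound 2 is clearly the tighter binder of the pair.

The step from compound 2 to compound 3 `CCCCC(=O)NCCCc1ccccc1OC` touches a single place: ethyl in place of hydrogen on a saturated chain carbon, two bonds along the chain from a carbonyl carbon. Put plainly, the chain on the amide side grows, from propanoyl to butylcarbonyl, while the ring, its methoxy group and the three-carbon link to the amide stay as they are.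

Among the compounds with values here, no measured pair differs in this way, so the size of the step has to be guessed. The expectation is a modest move toward weaker binding, a 2.1-fold higher number from compound 2 to compound 3 (0.33 log units; beyond the scatter). For compound 3 the estimated value in this assay is 800 nM, with a range from 200 nM to 3000 nM.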

Compound 3, inhibition constant: > 100000 nM
Compound 3 gave a limit, no number; the forecaster's own chance of this, stated with the estimate: 2%; middle value at least 120-fold (2.09 log units) from the limit.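

Putting ethyl in place of hydrogen on this saturated chain carbon, two bonds along the chain from a carbonyl carbon, gives an at least 260-fold higher number from compound 2 to compound 3 (2.42 log units; beyond the scatter) in this assay, so a single change on the amide side of the molecule can separate a measurable binder from a compound with no measured number. Compound 3 reads > 100000 nM, which is a limit of the assay and not a number. The step therefore marks only the smallest possible size of the change, and the full loss of binding cannot be read from it: the limit of > 100000 nM in this assay, at which 1 of the 3 values shown sits.

With only this one change at this place, the compounds shown cannot reveal whether binding falls gradually as the chain grows or drops sharply at a particular length, and a butanoyl group on the same core would help to settle that. From the compounds shown here alone, it also remains open how a shorter acetyl group, a branched isobutyryl group, or a chain ending in an amine or a carboxylic acid would behave at this place, so no general rule for this part of the molecule can yet be drawn.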